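A few compounds are considered here, and "the series" means these few. Any claim that something is new, unique, unknown or untested is made for them only; others in the source may bear on it.

Measured so far in an assay on CHO cells for agonist activity at Free fatty acid receptor 1 (Homo sapiens), read by FLIPR; on this read-out lower numbers stand for an effect already at smaller amounts and higher numbers for an effect only at larger amounts of compound:
- compound 1, `Cc1nc(-c2cccc(F)c2)sc1COc1ccc(OCC(=O)O)c(F)c1`: 185 nM
- compound 2, `O=C(O)COc1ccc(OCc2nc(-c3ccccc3)cs2)cc1F`: > 10000 nM
- compound 3, `O=C(O)COc1ccc(OCc2nnc(-c3ccccc3)s2)cc1F`: > 10000 nM

Going by the values given here, of the three values, only that of compound 1 is a number. For compound 2 the result in this assay is a limit of the assay, > 10000 nM, and not a measured concentration. For compound 3 the result is likewise a limit, > 10000 nM, so compound 3 stands at the limit of > 10000 nM in this assay, at which 2 of the 3 values shown sit, rather than at a known point of the scale. Among the compounds with values here, no step between two measured compounds that differ in one place is available, so the series gives no measured size for any single change.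

Compound 4, `Cc1cc(OCc2nnc(-c3ccccc3)s2)ccc1OCC(=O)O`, has not yet been measured in this assay. It differs from compound 3 by methyl in place of fluoro on an aromatic carbon, ortho to the carboxymethoxy group and meta to a large group. The core carrying the phenyl-substituted five-membered ring is kept. Within the data shown here, since compound 3 sits at the limit and compound 1, which carries the same fluoro, is the only compound with a number, a small exchange on the acid-bearing ring is not expected to move the result far. Compound 4 is estimated at 10000 nM, within 3000 nM to 30000 nM, and the expected step of a number no higher from compound 3 to compound 4 (the limit leaves the size open) is none beyond the scatter, with a fair chance that the assay again reports only a limit.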

Compound 4, half-maximal effective concentration: > 10000 nM
Compound 4 ended at the assay's limit; the forecaster's own chance of this, stated with the estimate: 65%; the middle value sits exactly at the limit.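

Compound 3 and compound 4 both end at a limit of the assay rather than at a number, so methyl in place of fluoro on an aromatic carbon gives no readable step between them: the limit of > 10000 nM in this assay, at which 3 of the 4 values shown sit.

The compounds shown leave open how large this exchange is, and in which direction it moves the result.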